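Two Sulfonylguanidines Measured, a Third Awaits Its Number

The compounds below may be only part of what the source reports. "The series", "measured", "known", "first", "only" and "open" are said of these compounds alone.

Compound 1 `Cc1cc(-c2ccccc2)n(/C(N)=N/S(=O)(=O)c2cc(C)c(Cl)cc2SCc2cccc3ccccc23)n1`: 12000 nM
Compound 2 `Cc1cc(S(=O)(=O)/N=C(\N)n2nccc2-c2ccccc2)c(SCc2cccc3ccccc23)cc1Cl`: 11000 nM

Both compounds were measured in an ADME assay on HaCaT cells (Homo sapiens) for cytotoxicity, read by MTT assay, with a stated time of 72 h; a lower number here means a stronger inhibitor, a higher number a weaker inhibitor. Compound 2 gives the lower of the two numbers, but the gap to compound 1 is small: the step of a 1.1-fold lower number from compound 1 to compound 2 (0.04 log units; within the scatter) lies within the scatter, so the two compounds are not told apart by this assay.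

Compound 3 `Cc1cc(S(=O)(=O)/N=C(\N)n2nccc2-c2ccccc2)c(SCc2ccc(Cl)cc2)cc1Cl` has not yet been measured in this assay. It differs from compound 2 in one place: 4-chlorophenyl in place of naphthalen-1-yl on a saturated chain carbon bound to a sulfur. Within the data shown here, no measured step touches this position; the only step in hand, that from compound 1 to compound 2, concerns a methyl on an aromatic carbon elsewhere in the shared core and does not bear on the exchange of the group on the sulfur-bound carbon. With nothing to point either way, the expectation for compound 3 is a number close to that of compound 2, the expected step of a 1.2-fold higher number from compound 2 to compound 3 (0.07 log units; within the scatter) being no larger than the scatter. The estimate for compound 3 in this assay is 13000 nM, with a range from 5000 nM to 35000 nM.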

Compound 3, half-maximal inhibitory concentration: 12000 nM
The estimate for compound 3 lay 1.1-fold (0.03 log units) above the measured number, and the stated range covers the measured number.
By their numbers in this assay, from the lowest: compounds 2, 1 and 3 (each within the scatter of the next).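

In this assay, among these compounds, the exchange of naphthalen-1-yl for 4-chlorophenyl on a saturated chain carbon bound to a sulfur gives a 1.1-fold higher number from compound 2 to compound 3 (0.04 log units; within the scatter) and so provides the first reading at this position, which the earlier step on the aromatic methyl did not touch. The exchange takes the group from two six-membered aromatic rings of carbon only to one, and from 10 heavy atoms to 7, one of them chlorine, yet the numbers for compound 2 and compound 3 lie within the scatter of each other and this assay does not tell the two groups apart. Nothing in the data shown offers a reason for this result.

On these data alone, the position has so far been read only with these two groups, both without hydrogen-bond donors or acceptors, so it remains open whether an amine, a carboxylic acid or a longer chain on the same carbon would also give a number within the scatter of compound 2. As far as these compounds go, it is also open whether the exchange of methyl for hydrogen on the aromatic carbon would read the same with 4-chlorophenyl in place as it did with naphthalen-1-yl.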